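The source may report more compounds than this note shows. Statements on the series, on what has been measured and on what is new or still open speak of the compounds shown alone.

Measured compounds:
- Compound 1, `Cc1n[nH]c(N)c1-c1ccc(Cl)cc1`: in an assay on Sf9 cells for inhibition of mitogen-activated protein kinase kinase kinase 14 (Homo sapiens), read by ADP-Glo, with a stated time of 60 min (a lower number here means a stronger inhibitor, a higher number a weaker inhibitor), compound 1 gives 61100 nM.
- Compound 2, `Cc1[nH]nc(N)c1-c1ccc(Br)cc1`: in this assay compound 2 gives > 100000 nM, which is a limit of the assay and not a number.
- Compound 3, `CCCC(=O)n1nc(C)c(-c2ccc(Cl)c(Cl)c2)c1N`: in this assay compound 3 gives > 100000 nM, again a limit of the assay and not a number.

Compound 3 therefore stands at the weak end of what has been measured, at the limit of > 100000 nM in this assay, at which 2 of the 3 values shown sit, so its position on the scale is known only as a limit.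

Compound 4, `Cc1nn(C(=O)C2CCCC2)c(N)c1-c1ccc(Cl)c(Cl)c1`, differs from compound 3 in one place: cyclopentyl in place of propyl on a carbonyl carbon. Among the compounds with values here, no step between measured compounds bears on this change, so nothing here shows whether a larger group on that carbonyl carbon moves the value. The change is expected to give a step in this assay of a number no higher from compound 3 to compound 4 (the limit leaves the size open), which means none beyond the scatter. Compound 4 is accordingly estimated at 100000 nM, with a range from 40000 nM to 300000 nM, and most likely the assay will again report only a limit.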

Compound 4, half-maximal inhibitory concentration: 41000 nM
Compound 4: middle estimate off by 2.4-fold (0.39 log units), on the high side, and the stated range covers the measured number.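

In this assay, cyclopentyl in place of propyl on the carbonyl carbon gives an at least 2.4-fold lower number from compound 3 to compound 4 (0.38 log units; beyond the scatter). Within the data shown here, this is the first step that can be read at this position, and it shows that the group on this carbonyl carbon can move the read-out, with compound 4 giving 41000 nM. The value of compound 3 is a limit of the assay and not a number, so the true size of the step stays unknown: the limit of > 100000 nM in this assay, at which 2 of the 4 values shown sit.

The compounds shown do not separate the effect of the ring from that of the added carbons, a question that a straight pentyl chain on the same carbonyl carbon would address. Going by these compounds, how a cyclohexyl group or a group carrying an amine at this position would read also remains open.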